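Amide substituent change on a chromone cytotoxicity series

This account rests on a few compounds, and the source may have more. Where it says the series, first, only, none or still open, it means among the compounds named here.

Compound 2 `COc1cccc(NC(=O)/C=C/c2coc3cc(OC)ccc3c2=O)c1` shows the highest of the two numbers measured in an ADME assay on HepG2 2.2.15 cells (Homo sapiens) for cytotoxicity, read by MTT assay, with stated times of 48 h and 9 days (on this read-out higher numbers stand for lower toxicity in this test and lower numbers for higher toxicity in this test), giving 1130000 nM. For the measured compounds named here, the nearest is compound 1 `COc1ccc2c(=O)c(/C=C/C(=O)NCc3cccc(F)c3)coc2c1`, which in this assay gives 475000 nM; the step of a 2.4-fold higher number from compound 1 to compound 2 (0.38 log units; beyond the scatter) is the only measured step and involves the same amide-type nitrogen. Compound 3 `COc1ccc2c(=O)c(/C=C/C(=O)Nc3ccccc3C)coc2c1` differs from compound 2 by 2-methylphenyl in place of 3-methoxyphenyl on an amide-type nitrogen. Going by the values given here, because the one step of a 2.4-fold higher number from compound 1 to compound 2 (0.38 log units; beyond the scatter) was modest and concerned a different exchange at this nitrogen, no change beyond the scatter is expected here, though the estimate allows for a modest drop. Compound 3 is estimated to give 800000 nM, within 400000 nM to 1600000 nM, an expected step of a 1.4-fold lower number from compound 2 to compound 3 (0.15 log units; within the scatter).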

Compound 3, half-maximal cytotoxic concentration: 59700 nM
Compound 3: the middle estimate sits 13-fold (1.13 log units) above what was measured; the measured number lies below the stated range.
By their numbers in this assay, from the lowest: compound 3; then compound 1; then compound 2.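

In this assay the amide-type nitrogen proves far more sensitive than the first exchange showed: 2-methylphenyl in place of 3-methoxyphenyl gives a 19-fold lower number from compound 2 to compound 3 (1.28 log units; beyond the scatter) and 2-methylphenyl in place of 3-fluorobenzyl gives an 8.0-fold lower number from compound 1 to compound 3 (0.90 log units; beyond the scatter) at the same nitrogen. Among these three groups, 2-methylphenyl goes with the lowest number, which here stands for the highest toxicity in this test. Nothing available explains this difference.

From the compounds shown here alone, it remains open whether 3-methylphenyl would track 2-methylphenyl or 3-methoxyphenyl. Going by these compounds, the effect of a carboxylic acid on the phenyl ring at this nitrogen also remains open.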